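This account rests on a few compounds, and the source may have more. Where it says the series, first, only, none or still open, it means among the compounds named here.

Measured compounds:
- compound 1 `O=C(NO)C(F)(F)C(F)(F)C(F)(F)C(F)(F)C(F)(F)C(F)(F)C(=O)Nc1cccc(-c2ccccc2)c1`, in an ADME assay on isolated protein for inhibition of histone deacetylase 5 (Homo sapiens), read by fluorescence, with stated times of 30 min and 60 min (a higher number here means a weaker inhibitor, a lower number a stronger inhibitor), compound 1 gives > 50000 nM, a limit of the assay.
- compound 2 `O=C(NO)C(F)(F)C(F)(F)C(F)(F)C(F)(F)C(F)(F)C(F)(F)C(=O)Nc1ccccc1-c1ccccc1`, in this assay compound 2 gives > 50000 nM, also a limit.

Where compound 2 stands: only a limit is known for it, and the one other value in the series is a limit as well; both sit at the limit of > 50000 nM in this assay, at which 2 of the 2 values shown sit. Within the data shown here, the single step measured so far, a step that the two limits leave unreadable from compound 1 to compound 2, therefore cannot be read for size or direction, and nothing shows a readable difference.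

The next compound, compound 3 `O=C(NO)C(F)(F)C(F)(F)C(F)(F)C(F)(F)C(F)(F)C(F)(F)C(=O)Nc1nc(-c2ccccc2)cs1`, differs from compound 2 by 4-phenyl-1,3-thiazol-2-yl in place of 2-phenylphenyl on an amide-type nitrogen.

Among the measured compounds shown here, no measured step bears on this change in a readable way: the only comparison available is between two limits, so there is no basis for expecting a step in this assay in either direction beyond the scatter. The working expectation is simply that compound 3 most likely stays where the measured compounds stand, with the step that the limit leaves unreadable from compound 2 to compound 3 expected to be small or unreadable. The estimate for compound 3 is 70000 nM, within a range from 8000 nM to 600000 nM, with a high chance that again only a limit is reported.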

Compound 3, inhibition constant: > 50000 nM
Compound 3 ended at the assay's limit; the forecaster's own chance of this, stated with the estimate: 75%; the middle value is on the limit's open side.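

In this assay compound 3 gives > 50000 nM, a limit of the assay. No step among compound 1, compound 2 and compound 3 can be read for size or direction: the limit of > 50000 nM in this assay, at which 3 of the 3 values shown sit.

The compounds shown leave open whether any group on the amide-type nitrogen gives a measurable value in this assay.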